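A few compounds are considered here, and "the series" means these few. Any claim that something is new, unique, unknown or untested is made for them only; others in the source may bear on it.

Measured compounds:
compound 1, `C[C@@H]1CN(C(=O)c2nc(Nc3cc(C4CC4)[nH]n3)c3cc(Cl)ccc3n2)CCN1C(=O)OC(C)(C)C`, with 36.4% in an assay for inhibition of serine/threonine-protein kinase PAK 4 (Homo sapiens), read by FRET and Z'-LYTE, with a stated time of 60 min, tested at 50 uM, in the presence of a further agent that is not named here; a lower number here means a weaker effect, a higher number a stronger effect of the compound at the concentration tested
compound 2, `CC(OC(=O)N1CCN(C(=O)c2nc(Nc3cc(C4CC4)[nH]n3)c3cc(Cl)ccc3n2)C[C@H]1C)OC(=O)C(C)(C)C`, with 65.3% in this assay

Among the measured compounds shown here, compound 2 stands highest of the two numbers so far; its nearest neighbour is compound 1, and the gap between them is a number 28.9 percentage points higher from compound 1 to compound 2 (beyond the scatter), a step beyond the scatter that came with 1-(((tert-butyl)carbonyl)oxy)ethyl in place of tert-butyl on an oxygen next to a carbonyl group.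

Compound 3 is `C[C@@H]1CN(C(=O)c2nc(Nc3cc(C4CC4)[nH]n3)c3cc(Cl)ccc3n2)CCN1C(=O)OCc1ccccc1`. It differs from compound 2 at the same place: benzyl in place of 1-(((tert-butyl)carbonyl)oxy)ethyl on an oxygen next to a carbonyl group. For the measured compounds named here, the only measured step, from compound 1 to compound 2, concerns a different group entering at this oxygen, so it does not show what a benzyl there does. It does show that this position is sensitive, since the step there was well beyond the scatter. Going by the values given here, with no direct precedent, the expectation for compound 3 is loosely held, somewhere between the two measured numbers, which means an expected step of a number 20.3 percentage points lower from compound 2 to compound 3 (beyond the scatter). The estimate for compound 3 in this assay is 45%, with a range from 20% to 70%.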

Compound 3, a percentage reported as inhibition, at one concentration (the size of the read-out at that concentration, not a potency): 96%
The estimate for compound 3 lay 51 percentage points below the measured number; measured number above the stated range.
By their numbers in this assay, from the lowest: compound 1; then compound 2; then compound 3.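

Compound 3 stands highest of the three, since in this assay benzyl in place of 1-(((tert-butyl)carbonyl)oxy)ethyl on an oxygen next to a carbonyl group gives a number 30.7 percentage points higher from compound 2 to compound 3 (beyond the scatter) and benzyl in place of tert-butyl gives a number 59.6 percentage points higher from compound 1 to compound 3 (beyond the scatter) as well. The position therefore tolerates an aromatic ring here, and the group with this ring, which carries no hydrogen-bond acceptors, outdoes the ringless group with hydrogen-bond acceptors, so acceptors in this group are not needed for a high read-out. Nothing shown here gives a measured reason for this order.

Benzyl is the only group with a ring among these compounds, so the ring cannot yet be separated from the other features of the group, and a 2-phenylethyl group, with a longer chain to the ring, or a pyridin-2-ylmethyl group, with a nitrogen in the ring, would test how much the ring and its distance from the oxygen matter. On these data alone, these read-outs also come from one concentration and are not potencies, so how far compound 3 truly exceeds the others remains open.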